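Valine in place of lysine on a cyclopropyl purine amide

A few compounds are considered here, and "the series" means these few. Any claim that something is new, unique, unknown or untested is made for them only; others in the source may bear on it.

Compound 1 `O=C(CN(c1nc(Cl)nc2[nH]cnc12)C1CC1)N[C@@H](CO)C(=O)O` is the stronger of the two measured compounds: in a functional assay on the whole organism (Tail, strain ICR) with Mus musculus as the target, in the tail flick test, with a stated time of 120 min, at a dose of 25 umol/kg by the oral route (on this read-out higher numbers stand for a stronger effect at the one dose given and lower numbers for a weaker effect), compound 1 gives 39%. Compound 2 `NCCCC[C@H](NC(=O)CN(c1nc(Cl)nc2[nH]cnc12)C1CC1)C(=O)O`, which carries 3-aminopropyl in place of hydroxy on a saturated chain carbon, two bonds along the chain from an amide-type nitrogen and a carbonyl carbon, gives 16.4% in this assay, the lower of the two numbers; the step of a number 22.6 percentage points lower from compound 1 to compound 2 (beyond the scatter) lies beyond the scatter. Compound 3 `CC(C)[C@H](NC(=O)CN(c1nc(Cl)nc2[nH]cnc12)C1CC1)C(=O)O` has not yet been measured. It differs from compound 2 as follows: isopropyl in place of 4-aminobutyl on a saturated chain carbon bound to an amide-type nitrogen and a carbonyl carbon. Among the measured compounds shown here, the only measured step that touches this chain carbon is a number 22.6 percentage points lower from compound 1 to compound 2 (beyond the scatter), where removing the 4-aminobutyl's relative in favour of hydroxy was accompanied by a modest gain; no measured step covers an isopropyl there. The estimate for compound 3 in this assay is therefore a step of a number 11.6 percentage points higher from compound 2 to compound 3 (beyond the scatter) from compound 2, with wide uncertainty. The expected value for compound 3 is 28%, within a range from 8% to 50%.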

Compound 3, a percentage reported as activity, at one dose (the size of the read-out at that dose, not a potency): 17.1%
The estimate for compound 3 lay 10.9 percentage points above the measured number, and the stated range covers the measured number.
By their numbers in this assay, from the lowest: compounds 2 and 3 (each within the scatter of the next); then compound 1.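

In this assay, the step of a number 0.7 percentage points higher from compound 2 to compound 3 (within the scatter) shows that 4-aminobutyl and isopropyl on this saturated chain carbon cannot be told apart, although only 4-aminobutyl carries a nitrogen. The step of a number 21.9 percentage points lower from compound 1 to compound 3 (beyond the scatter) then matches the earlier one in direction, so hydroxymethyl stands apart from both of the other groups. Among the compounds shown here, the single earlier step could not show this: the change from hydroxymethyl is now seen with two different groups, one with an amine and one purely of carbon.

On these data alone, it remains open whether a carboxylic acid or a shorter chain ending in an amine at this carbon would read like hydroxymethyl or like the other two groups. Nothing available here accounts for the separation of hydroxymethyl from the other two groups.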